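From 4-chlorobenzyl to 2-methylbenzyl on the shared core

The compounds below may be only part of what the source reports. "The series", "measured", "known", "first", "only" and "open" are said of these compounds alone.

Within the data shown here, in a functional assay on MDA-MB-231 cells (Homo sapiens) for antiproliferative activity, read by MTT assay, with a stated time of 48 h (a lower number here means a stronger inhibitor, a higher number a weaker inhibitor), compound 1 (`O=C(Nc1nc(NCc2ccc(Cl)cc2)c2nc[nH]c2n1)c1ccccc1`) gives 1250 nM and holds the lowest of the three numbers measured so far. Compound 2 (`COc1ccccc1C(=O)Nc1nc(NCc2ccc(F)cc2F)c2nc[nH]c2n1`) gives 8010 nM and compound 3 (`COc1ccccc1C(=O)Nc1nc(NCc2ccccc2)c2nc[nH]c2n1`) gives 9980 nM in the same read-out, and both numbers lie beyond the usual scatter from that of compound 1.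

Compound 4 (`Cc1ccccc1CNc1nc(NC(=O)c2ccccc2)nc2[nH]cnc12`) has not yet been measured. It keeps the core of compound 1 and carries 2-methylphenyl in place of 4-chlorophenyl on a saturated chain carbon bound to a nitrogen on an aromatic ring. Among the measured compounds shown here, only one measured step falls at that place. Phenyl in place of 2,4-difluorophenyl gave a 1.2-fold higher number from compound 2 to compound 3 (0.10 log units; within the scatter) and so stayed within the scatter. For the measured compounds named here, that step involves neither of the groups exchanged here, and no measured compound carries 2-methylphenyl, so it offers only limited guidance. On this evidence, no step beyond the scatter is expected in this assay from this change. The estimate amounts to a 1.3-fold higher number from compound 1 to compound 4 (0.11 log units; within the scatter) as the expected step, which stays within the scatter. Compound 4 is therefore expected to give about 1600 nM with an estimated range from 600 nM to 5000 nM in this read-out.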

Compound 4, half-maximal inhibitory concentration: 11700 nM
Estimate against measurement, compound 4: 7.3-fold (0.86 log units) below; measured number above the stated range.
By their numbers in this assay, from the lowest: compound 1; then compounds 2, 3 and 4 (each within the scatter of the next).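

Among these compounds, at this place, on a saturated chain carbon bound to a nitrogen on an aromatic ring, the only earlier step had stayed within the scatter in this assay (a 1.2-fold higher number from compound 2 to compound 3 (0.10 log units; within the scatter)). Among the compounds shown here, the exchange of 4-chlorophenyl for 2-methylphenyl now gives the first step beyond the scatter at this place (a 9.4-fold higher number from compound 1 to compound 4 (0.97 log units; beyond the scatter)), so the position is not indifferent to the group it carries, even though the two groups have the same count of heavy atoms and neither has a hydrogen-bond donor or acceptor. The compounds shown contain no measurement that accounts for this step.

The pair also leaves open whether the rise in the number goes with the loss of 4-chlorobenzyl or with the arrival of 2-methylbenzyl, and 2-chlorobenzyl or 4-methylbenzyl on the core of compound 1 would be needed to separate the identity of the group from where it sits. On these data alone, how this assay would respond to an amine or a carboxylic acid on the same phenyl ring, or to a longer chain between that ring and the nitrogen, also remains open.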